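A few compounds are considered here, and "the series" means these few. Any claim that something is new, unique, unknown or untested is made for them only; others in the source may bear on it.

Compound 1, `COc1ccc(Cc2cc(-c3ccc(Cl)cc3)nn(CC(=O)Nc3ccc(Br)cc3)c2=O)cc1`, in a functional assay on HL-60 cells (Homo sapiens), read by calcium flux (a lower number here means that less compound is needed, a higher number that more compound is needed for the effect), gives > 50000 nM, which is a limit of the assay and not a number.
Compound 2, `COc1cccc(Cc2cc(-c3ccc(Cl)cc3)nn(CC(=O)Nc3ccc(F)cc3)c2=O)c1`, in this assay gives > 50000 nM, again a limit of the assay.
Compound 3, `COc1ccc(Cc2cc(-c3ccc(C)cc3)nn(CC(=O)Nc3ccc(Br)cc3)c2=O)cc1`, in this assay gives > 50000 nM, also a limit of the assay.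

Compound 3 comes from compound 1 by a single change, (methyl in place of chloro on an aromatic carbon). The resulting step, a step that the two limits leave unreadable from compound 1 to compound 3, cannot be sized because of the limit of > 50000 nM in this assay, at which 3 of the 3 values shown sit. How the core of compound 2 differs from the core of compound 1 is not broken down here. Compound 4, `COc1cccc(Cc2cc(-c3ccc(C)cc3)nn(CC(=O)Nc3ccc(F)cc3)c2=O)c1`, is not yet measured; it stands to compound 2 exactly as compound 3 stands to compound 1, the same change at the same place: methyl in place of chloro on an aromatic carbon. In this assay the expected step is a number no higher from compound 2 to compound 4 (the limit leaves the size open), an expectation that rests only on the fact that (the limit of > 50000 nM in this assay, at which 3 of the 3 values shown sit). Compound 4 is therefore estimated at 50000 nM, with a plausible range from 15000 nM to 100000 nM.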

Compound 4, half-maximal effective concentration: > 50000 nM
Compound 4: no number, only a limit; the forecaster's own chance of this, stated with the estimate: 85%; the middle value sits exactly at the limit.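

No size can be read for the step between compound 2 and compound 4, because both sit at a limit of this assay rather than at a number: the limit of > 50000 nM in this assay, at which 4 of the 4 values shown sit. Going by these compounds, whether methyl in place of chloro changes the concentration needed at all remains open.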